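Methyl in place of chloro on compound 1

The compounds below may be only part of what the source reports. "The series", "measured", "known", "first", "only" and "open" are said of these compounds alone.

Of the compounds shown here, two on the shared core carry numbers so far. In a functional assay on CaEs17 cells (Homo sapiens) for inhibition, read by MTT assay (on this read-out lower numbers stand for stronger inhibition and higher numbers for weaker inhibition), compound 1 `C=C1C(=O)[C@@]23C(=O)OC[C@]4([C@@H](OC(C)=O)CCC(C)(C)[C@H]4C=O)[C@@H]2CC[C@H]1[C@H]3OC(=O)c1ccc(Cl)cc1` gives 1250 nM, the lower of the two numbers, and compound 2 `C=C1C(=O)[C@@]23C(=O)OC[C@]4([C@@H](OC(C)=O)CCC(C)(C)[C@H]4C=O)[C@@H]2CC[C@H]1[C@H]3OC(=O)CCCC` gives 2850 nM. Among the measured compounds shown here, the only measured step, butyl in place of 4-chlorophenyl on a carbonyl carbon, is a 2.3-fold higher number from compound 1 to compound 2 (0.36 log units; beyond the scatter), modest but beyond the scatter.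

Next in line is compound 3 `C=C1C(=O)[C@@]23C(=O)OC[C@]4([C@@H](OC(C)=O)CCC(C)(C)[C@H]4C=O)[C@@H]2CC[C@H]1[C@H]3OC(=O)c1ccc(C)cc1`, which differs from compound 1 by methyl in place of chloro on an aromatic carbon, para to a large group: methyl in place of chloro on an aromatic carbon. The measured step bears on this only indirectly. It replaced the whole 4-chlorophenyl, whereas here the aromatic ring stays and one group on it changes. For the measured compounds named here, no measured step isolates that group. A shift in this assay larger than a 2.3-fold higher number from compound 1 to compound 2 (0.36 log units; beyond the scatter) is therefore not expected, and most likely none beyond the scatter, with a slight lean towards a higher number. The expected step is a 1.2-fold higher number from compound 1 to compound 3 (0.08 log units; within the scatter). For compound 3 the estimated value is 1500 nM, with an expected range from 750 nM to 3000 nM.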

Compound 3, half-maximal inhibitory concentration: 1830 nM
Compound 3: the middle estimate sits 1.2-fold (0.09 log units) below what was measured; measured number inside the range.
By their numbers in this assay, from the lowest: compounds 1, 3 and 2 (each within the scatter of the next, the first and the last beyond it).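

In this assay, the exchange of chloro for methyl on the aromatic carbon para to a large group gives a 1.5-fold higher number from compound 1 to compound 3 (0.17 log units; within the scatter) and so does not separate the two compounds, which makes this the first sign that the ring tolerates one of these two groups as well as the other. The comparison with the butyl ester now has a second reading: 4-methylphenyl in place of butyl on a carbonyl carbon gives a 1.6-fold lower number from compound 2 to compound 3 (0.19 log units; within the scatter) while the earlier exchange gives a 2.3-fold higher number from compound 1 to compound 2 (0.36 log units; beyond the scatter), so a separation of the aromatic esters from butyl beyond the scatter holds only for compound 1 and not for compound 3. No measurement on hand offers a reason for either step.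

Open, from the compounds shown here alone, is whether a group of another kind on the same aromatic carbon, such as a methoxy, a nitro, an amine or a carboxylic acid, would move the number beyond the scatter, or whether only chloro and methyl behave alike there. Also open, going by these compounds, is how an unsubstituted phenyl ester or a longer chain than butyl on the carbonyl carbon would stand against compound 1 and compound 2.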